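The source may report more compounds than this note shows. Statements on the series, on what has been measured and on what is new or still open speak of the compounds shown alone.

Compound 1 `[N-]=[N+]=N[C@@H]1C(n2ccc(=O)[nH]c2=O)[Se][C@H](CO)[C@H]1O` is tested in a functional assay on SNU-638 cells (Homo sapiens) for cytotoxicity, read by sulforhodamine B assay; a higher number here means a weaker inhibitor, a lower number a stronger inhibitor. There compound 1 gives only a limit, > 100000 nM. Compound 2 `[N-]=[N+]=N[C@@H]1C(n2cc(F)c(=O)[nH]c2=O)[Se][C@H](CO)[C@H]1O` likewise gives a limit in this assay, > 100000 nM. Compound 3 `[N-]=[N+]=N[C@@H]1C(n2cc(Cl)c(=O)[nH]c2=O)[Se][C@H](CO)[C@H]1O` also gives a limit there, > 100000 nM. The steps a step that the two limits leave unreadable from compound 1 to compound 2, a step that the two limits leave unreadable from compound 1 to compound 3 and a step that the two limits leave unreadable from compound 2 to compound 3 therefore cannot be read, because every value sits at the limit of > 100000 nM in this assay, at which 3 of the 3 values shown sit. Compound 4 `[N-]=[N+]=N[C@@H]1C(n2cc(Br)c(=O)[nH]c2=O)[Se][C@H](CO)[C@H]1O` differs from compound 1 by bromo in place of hydrogen on an aromatic carbon. The measured steps from compound 1 to compound 2 and from compound 1 to compound 3 bear directly on this change, yet their size is hidden by the limit, so nothing beyond the likelihood of another limit guides the expectation. Compound 4 is accordingly expected at 200000 nM (range 50000 nM to 1000000 nM), an estimated step that the limit leaves unreadable from compound 1 to compound 4.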

Compound 4, half-maximal inhibitory concentration: > 100000 nM
Compound 4: only a limit was reported; the forecaster's own chance of this, stated with the estimate: 85%; the middle value does not contradict the limit.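

No step from compound 1, compound 2 or compound 3 to compound 4 can be read in this assay, because each value is only a limit: the limit of > 100000 nM in this assay, at which 4 of the 4 values shown sit.

The compounds shown leave open whether hydrogen, fluoro, chloro and bromo differ at all in this position.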